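The source may report more compounds than this note shows. Statements on the series, on what has been measured and on what is new or still open speak of the compounds shown alone.

Compound 1, `Nc1ccccc1NC(=O)c1ccc(Cn2cnc3c(Nc4ccccc4)nc(Cl)nc32)cc1`, in a functional assay on HCT-116 cells (Homo sapiens) for antiproliferative activity, read by CCK-8 assay, with a stated time of 72 h (on this read-out lower numbers stand for stronger inhibition and higher numbers for weaker inhibition), gives 1070 nM.
Compound 2, `CCCCn1cnc2c(Nc3ccccc3)nc(NCOCc3ccc(C(=O)Nc4ccccc4N)cc3)nc21`, in this assay gives 1190 nM.
Compound 3, `Nc1ccccc1NC(=O)c1ccc(Cn2cnc3c(Nc4cccc(Cl)c4)nc(Cl)nc32)cc1`, in this assay gives 2340 nM.

Compound 1 and compound 3 differ in one place only: chloro in place of hydrogen on an aromatic carbon. That change brings a 2.2-fold higher number from compound 1 to compound 3 (0.34 log units; beyond the scatter), a modest step but one that goes beyond the usual scatter of this kind of measurement. Compound 1 and compound 2 carry different cores; the difference between the two cores is not broken down here. Their values in this assay lie within the scatter of each other, so nothing can be said about their order.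

Compound 4, `CCCCn1cnc2c(Nc3cccc(Cl)c3)nc(NCOCc3ccc(C(=O)Nc4ccccc4N)cc3)nc21`, has not yet been measured. It stands to compound 2 as compound 3 stands to compound 1: chloro in place of hydrogen on an aromatic carbon. The place of the change is described in the same words in both pairs, so this is the same change made on a different core.

On the strength of the step from compound 1 to compound 3, compound 4 is expected to show a 2.2-fold higher number from compound 2 to compound 4 (0.34 log units; beyond the scatter) in this assay, since the only shown example of this change, a 2.2-fold higher number from compound 1 to compound 3 (0.34 log units; beyond the scatter), weakened inhibition. Compound 4 is therefore estimated to give about 2600 nM, with a likely range from 1300 nM to 5500 nM, resting on a single precedent and on the core change being unexamined.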

Compound 4, half-maximal inhibitory concentration: 2120 nM
The estimate for compound 4 lay 1.2-fold (0.09 log units) above the measured number; measured number inside the range.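

On the core of compound 2, chloro in place of hydrogen on the aromatic carbon gives a 1.8-fold higher number from compound 2 to compound 4 (0.25 log units; within the scatter) in this assay, so this step taken alone cannot be told apart from the scatter of repeated measurements. Set beside the step on the core of compound 1, it shows that the change behaves alike on both cores as far as this read-out can tell: the same change on two cores in this assay, a 2.2-fold higher number (0.34 log units; beyond the scatter) from compound 1 to compound 3 and a 1.8-fold higher number (0.25 log units; within the scatter) from compound 2 to compound 4, 1.2-fold (0.09 log units) apart, within the scatter of two such steps This supports carrying the change between these two cores without a detectable difference in step size, but it does not show that the step is identical on both, that the core of compound 2 independently confirms weaker inhibition, or that the result holds for any core beyond these two.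

The compounds shown leave open whether phenyl to 3-chlorophenyl is a special case or whether a fluorine, a methyl or a methoxy group at the same place would give a similar step on both cores. They also leave open how a third core would respond, for example one carrying a longer chain or an amine, and what separately contributes to the difference between the two cores.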